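The source may hold more compounds than are shown below. What is called first, only, known or untested is meant among the compounds shown, and "the series" means these compounds.

In a functional assay on A2780 cells (Homo sapiens) for inhibition (on this read-out higher numbers stand for weaker inhibition and lower numbers for stronger inhibition), compound 1 `C[C@@H](C(=O)Nc1cc(C2CC2)[nH]n1)c1ccc(N2CCNC2=O)cc1` gives 13200 nM, while compound 2 `CC(C(=O)Nc1cc(C2CC2)[nH]n1)c1ccc(N2CCNC2=O)cc1` gives 2250 nM. Compound 2 therefore holds the lower number of the two and is the stronger inhibitor so far. Going by the values given here, the measured step between them is a 5.9-fold lower number from compound 1 to compound 2 (0.77 log units; beyond the scatter), and the only thing separating the pair is the fact that one of compounds 1 and 2 is drawn with a defined configuration and the other without, at the place where they differ.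

Compound 3 `CC(C(=O)Nc1cc(C2CC2)[nH]n1)c1ccc(N2CC(=O)NC2=O)cc1` keeps the rest of compound 2 but carries 2,4-dioxoimidazolidin-1-yl in place of 2-oxoimidazolidin-1-yl, on an aromatic carbon of a six-membered aromatic ring of carbon only, para to a large group: 2,4-dioxoimidazolidin-1-yl in place of 2-oxoimidazolidin-1-yl on an aromatic carbon.

Among the compounds with values here, the single measured step bears on this change only loosely. It concerns a stereocentre at a saturated chain carbon, not this group, so it offers no direct guide to direction, only a modest sense of how far a small alteration can move the number. Within the data shown here, with no measured example of the ring change, no shift beyond the scatter is expected, and the expected step is a 1.2-fold higher number from compound 2 to compound 3 (0.09 log units; within the scatter). Compound 3 is estimated at 2800 nM, with an expected range from 800 nM to 9500 nM.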

Compound 3, half-maximal inhibitory concentration: 4540 nM
Estimate against measurement, compound 3: 1.6-fold (0.21 log units) below, within the range that was stated.
By their numbers in this assay, from the lowest: compounds 2 and 3 (each within the scatter of the next); then compound 1.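

Going by these compounds alone, this is the first measured change at this place on the aromatic ring, and in this assay it gives a 2.0-fold higher number from compound 2 to compound 3 (0.30 log units; within the scatter), so this read-out does not separate the two compounds. Both are drawn without a configuration at the stereocentre, so the comparison is like for like: 2,4-dioxoimidazolidin-1-yl has one more heavy atom and one more hydrogen-bond acceptor than 2-oxoimidazolidin-1-yl, and the number stays within the scatter. Within the data shown here, nothing measured here explains this result, as the only evidence available concerns the stereocentre rather than the ring on the aromatic carbon.

On these data alone, a single change at this place shows little about how much variation it can accept, and how a morpholine ring or a carboxylic acid on the same aromatic carbon would read remains open. Also open is whether a form of compound 3 drawn with a defined configuration would follow the step seen at the stereocentre (a 5.9-fold lower number from compound 1 to compound 2 (0.77 log units; beyond the scatter)), since the compounds shown test that stereocentre only with 2-oxoimidazolidin-1-yl in place.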